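The source may report more compounds than this note shows. Statements on the series, on what has been measured and on what is new or still open speak of the compounds shown alone.

Three compounds sharing one core differ only in the substituted phenyl group on the amide-type nitrogen. In an ADME assay on HUVEC cells (Homo sapiens) for cytotoxicity, read by MTT assay, with a stated time of 72 h (on this read-out higher numbers stand for weaker inhibition and lower numbers for stronger inhibition), compound 1 (`COc1ccccc1NC(=O)CCC(=O)OCCCCCCSc1ccc([N+](=O)[O-])c2nonc12`) gives 1610 nM, compound 2 (`O=C(CCC(=O)OCCCCCCSc1ccc([N+](=O)[O-])c2nonc12)Nc1cccc(Cl)c1`) gives 1090 nM and compound 3 (`COc1ccc(NC(=O)CCC(=O)OCCCCCCSc2ccc([N+](=O)[O-])c3nonc23)cc1`) gives 1590 nM. Compound 3 therefore stands within the scatter of both of the others.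

Compound 4 (`O=C(CCC(=O)OCCCCCCSc1ccc([N+](=O)[O-])c2nonc12)NCCN1CCCC1`) has not yet been measured. It carries 2-(pyrrolidin-1-yl)ethyl in place of 4-methoxyphenyl on the amide-type nitrogen, a difference that reads in full: 2-(pyrrolidin-1-yl)ethyl in place of 4-methoxyphenyl on an amide-type nitrogen.

The measured steps bearing on this change are a 1.0-fold lower number from compound 1 to compound 3 (0.01 log units; within the scatter), a 1.5-fold higher number from compound 2 to compound 3 (0.16 log units; within the scatter) and a 1.5-fold lower number from compound 1 to compound 2 (0.17 log units; within the scatter). Each of them exchanges one substituted phenyl group for another, and none replaces the phenyl group with a non-aromatic one. They therefore offer only indirect guidance, and the data give no direction for the new group. No shift beyond the scatter is expected, although the uncertainty is wider than among the three measured compounds. The expected change is a 1.1-fold lower number from compound 3 to compound 4 (0.06 log units; within the scatter). For compound 4 the estimated value is 1400 nM, with an expected range from 500 nM to 4000 nM.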

Compound 4, half-maximal inhibitory concentration: 6070 nM
Compound 4: the middle estimate sits 4.3-fold (0.64 log units) below what was measured, outside the stated range (above it).
By their numbers in this assay, from the lowest: compounds 2, 3 and 1 (each within the scatter of the next); then compound 4.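

Among the compounds shown here, at the amide-type nitrogen, the earlier compounds offered only exchanges of one substituted phenyl group for another, all within the scatter, so the position could have seemed indifferent to what stands there. In this assay, the first non-aromatic group shows that it is not: a 3.8-fold higher number from compound 3 to compound 4 (0.58 log units; beyond the scatter) and a 3.8-fold higher number from compound 1 to compound 4 (0.58 log units; beyond the scatter) and also a 5.6-fold higher number from compound 2 to compound 4 (0.75 log units; beyond the scatter) all lie beyond the scatter, which places compound 4, with its 2-(pyrrolidin-1-yl)ethyl group, clearly apart from the three phenyl amides, with the highest number of the four. No measurement among those shown accounts for this separation.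

With only one non-aromatic group on this nitrogen, the compounds shown cannot separate the loss of the six-membered aromatic ring from the entry of the pyrrolidine ring or of its ethyl link. Going by these compounds, a plain butyl chain, a 2-phenylethyl group or a 2-(morpholin-4-yl)ethyl group on the same nitrogen would help to pull these parts apart, and whether the same step appears in cells other than those of this test also stays open.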